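Series notes: aryl swap from compound 3 to compound 4

The source may hold more compounds than are shown below. What is called first, only, known or untested is meant among the compounds shown, and "the series" means these compounds.

Compound 1 `NS(=O)(=O)c1ccc(NC(=S)Nc2ccc3ncnc(Nc4cccc(C(F)(F)F)c4)c3c2)cc1`: 7590 nM in a functional assay on NCI-H1975 cells (Homo sapiens) for antiproliferative activity, read by MTT assay, with a stated time of 72 h; a lower number here means a stronger inhibitor, a higher number a weaker inhibitor
Compound 2 `NS(=O)(=O)c1ccc(NC(=S)Nc2ccc3ncnc(Nc4ccc(F)c(Br)c4)c3c2)cc1`: 9980 nM in this assay
Compound 3 `NS(=O)(=O)c1ccc(NC(=S)Nc2ccc3ncnc(Nc4cccc(Br)c4)c3c2)cc1`: 11000 nM in this assay

Compound 3 gives 11000 nM in this assay. Its two steps to the other measured compounds, a 1.1-fold higher number from compound 2 to compound 3 (0.04 log units; within the scatter) and a 1.4-fold higher number from compound 1 to compound 3 (0.16 log units; within the scatter), both fall within the scatter, so on these numbers the three measured compounds cannot be told apart.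

Compound 4 `NS(=O)(=O)c1ccc(NC(=S)Nc2ccc3ncnc(Nc4ccc(C(F)(F)F)cc4)c3c2)cc1` differs from compound 3 by 4-(trifluoromethyl)phenyl in place of 3-bromophenyl on a nitrogen on an aromatic ring. For the measured compounds named here, two measured steps bear on this. The exchange of bromo for trifluoromethyl on the aromatic carbon, a 1.4-fold higher number from compound 1 to compound 3 (0.16 log units; within the scatter), was within the scatter, as was the whole-aryl swap a 1.3-fold higher number from compound 1 to compound 2 (0.12 log units; within the scatter). Going by these compounds, neither pair, however, covers the part of the change in which the trifluoromethyl group enters as 4-(trifluoromethyl)phenyl rather than the 3-(trifluoromethyl)phenyl carried by compound 1; that part is untested.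

Given that every aryl change measured so far stayed within the scatter, the expected step in this assay is a 1.2-fold lower number from compound 3 to compound 4 (0.06 log units; within the scatter), with no movement beyond the scatter anticipated. Compound 4 is therefore estimated at 9500 nM in this assay, with a range of 4000 nM to 25000 nM reflecting the unmeasured shift of the trifluoromethyl group.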

Compound 4, half-maximal inhibitory concentration: 17100 nM
For compound 4 the middle estimate is 1.8-fold (0.26 log units) below the measured one; low and high end bracket the measured number.
By their numbers in this assay, from the lowest: compounds 1, 2, 3 and 4 (each within the scatter of the next, the first and the last beyond it).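

In this assay, this position on the nitrogen gives its first step beyond the scatter, a modest one, when 4-(trifluoromethyl)phenyl replaces 3-(trifluoromethyl)phenyl (a 2.3-fold higher number from compound 1 to compound 4 (0.35 log units; beyond the scatter)), so the placement of the trifluoromethyl group on the aryl ring can register here although the earlier aryl changes could not be told apart. The change is not separated from the two bromo-bearing aryl groups (a 1.6-fold higher number from compound 3 to compound 4 (0.19 log units; within the scatter); a 1.7-fold higher number from compound 2 to compound 4 (0.23 log units; within the scatter)), which makes the pair with the same substituent the only one of the three new steps that is resolved. Nothing available explains this difference between the two trifluoromethyl-bearing aryl groups.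

Whether the effect of placement is tied to the trifluoromethyl group alone stays open: bromo appears only as 3-bromophenyl and 3-bromo-4-fluorophenyl, with no matching change of its place on the ring among these compounds. Also open is how groups of another kind on this aryl ring, such as a nitrile, a methoxy group or an amine, would read in this assay, as every aryl group shown carries only halogen or trifluoromethyl.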